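The source may hold more compounds than are shown below. What is called first, only, known or untested is meant among the compounds shown, and "the series" means these compounds.

The series shares one core, seen in compound 1 `COc1ccc(NC(=O)CN(c2cc(Cl)ccc2OC)S(=O)(=O)c2ccccc2)cc1`, an arylsulfonamide with a glycinamide arm. In a functional assay on SH-SY5Y cells (Homo sapiens), read by MTT assay, with a stated time of 24 h (a lower number here means that less compound is needed, a higher number that more compound is needed for the effect), compound 1 gives 16200 nM. Compound 2 `COc1ccc(Cl)cc1N(CC(=O)Nc1ccccc1)S(=O)(=O)c1ccccc1` drops the methoxy from the aniline ring; in this assay compound 2 reaches only the limit of > 20000 nM. The step of an at least 1.2-fold higher number from compound 1 to compound 2 (0.09 log units; that floor lies within the scatter) therefore rests on a floor, a limit at the limit of > 20000 nM in this assay, at which 1 of the 3 values shown sits. Compound 3 `COc1ccc(Cl)cc1N(CC(=O)N(C1CCCCC1)C1CCCCC1)S(=O)(=O)c1ccccc1` carries a dicyclohexyl amide and in this assay compound 3 gives 14300 nM; of the two numbers shown it is the lower, yet the gap to compound 1 lies within the scatter.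

Compound 4 `COc1ccc(Cl)cc1N(CC(=O)NC1CCCCC1)S(=O)(=O)c1ccccc1` differs from compound 3 by hydrogen in place of cyclohexyl on an amide-type nitrogen. No measured step touches the amide nitrogen: the only step shown concerns a methoxy on an aromatic carbon, and it sits within the scatter. What compounds 1 and 3 show is that an aryl secondary amide and a dicyclohexyl tertiary amide land within the scatter of each other, so little movement is expected from a 1.1-fold higher number from compound 3 to compound 4 (0.05 log units; within the scatter). Compound 4 is therefore estimated at 16000 nM, with a range from 7000 nM to 40000 nM, and a real chance that only a limit is reported.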

Compound 4, half-maximal effective concentration: 17600 nM
Estimate against measurement, compound 4: 1.1-fold (0.04 log units) below; low and high end bracket the measured number.
By their numbers in this assay, from the lowest: compounds 3, 1 and 4 (each within the scatter of the next). At a limit, above all of these: compound 2.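

At the amide-type nitrogen, hydrogen in place of cyclohexyl does not separate compound 4 from compound 3 in this assay, with a 1.2-fold higher number from compound 3 to compound 4 (0.09 log units; within the scatter), so this comparison gives no sign that the second cyclohexyl on this nitrogen matters for the read-out. The remaining group on the same nitrogen shows no separation either: cyclohexyl in place of 4-methoxyphenyl gives a 1.1-fold higher number from compound 1 to compound 4 (0.04 log units; within the scatter), so a saturated ring and a substituted aromatic ring cannot be told apart here. The comparison of cyclohexyl with phenyl, an at least 1.1-fold lower number from compound 2 to compound 4 (0.05 log units; that floor lies within the scatter), is weaker, resting on a limit of compound 2 and not on a number: the limit of > 20000 nM in this assay, at which 1 of the 4 values shown sits.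

Every step that can be read at this position thus stays within the scatter, and the compounds shown include no group on this nitrogen that moves the number beyond it. As far as these compounds go, whether an amine or a carboxylic acid carried on a longer chain at the amide-type nitrogen would do so remains open, as does the effect of any such change on the rest of the shared core.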